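A few compounds are considered here, and "the series" means these few. Any claim that something is new, unique, unknown or untested is made for them only; others in the source may bear on it.

Compound 1 `CC(C)Oc1ccc(C(=O)Nc2c(C(=O)O)nn(-c3ccc(Oc4ccccc4)cc3)c2-c2ccc(OC(C)C)cc2)cc1`: 140 nM
Compound 2 `CC(C)Oc1ccc(C(=O)Nc2c(C(=O)O)nn(-c3ccc(Oc4ccccc4)cc3)c2-c2ccc(OCc3ccccc3)cc2)cc1`: > 10000 nM

In an assay for displacement of a labelled ligand from Apoptosis regulator Bcl-2 (Homo sapiens), read by fluorescence polarization, with a stated time of 30 min (on this read-out lower numbers stand for stronger inhibition and higher numbers for weaker inhibition), compound 1 gives 140 nM. Compound 2 reaches only > 10000 nM, which is a limit of this assay and not a number, so compound 2 sits at the limit of > 10000 nM in this assay, at which 1 of the 2 values shown sits. Compound 3 `CC(C)Oc1ccc(C(=O)Nc2c(C(=O)O)nn(-c3ccc(C(C)C)cc3)c2-c2ccc(OCc3ccccc3)cc2)cc1` differs from compound 2 by isopropyl in place of phenoxy on an aromatic carbon. For the measured compounds named here, the single measured step, an at least 71-fold higher number from compound 1 to compound 2 (1.85 log units; beyond the scatter), concerns a different place on the shared core and so does not bear on this change. With nothing speaking for a shift in either direction, compound 3 is expected to stay near the limit, an estimated step that the limit leaves unreadable from compound 2 to compound 3. Compound 3 is thus estimated at 15000 nM, between 3000 nM and 60000 nM.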

Compound 3, inhibition constant: > 10000 nM
Compound 3 ended at the assay's limit (the forecaster's own chance of this, stated with the estimate: 75%); the middle value lies beyond the limit too.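

Compound 2 and compound 3 both end at a limit rather than a number, so the step between them cannot be read: the limit of > 10000 nM in this assay, at which 2 of the 3 values shown sit. As far as these compounds go, whether phenoxy or isopropyl on that aromatic carbon gives stronger inhibition stays open.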